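The compounds below may be only part of what the source reports. "The series", "measured", "known", "first", "only" and "open" are said of these compounds alone.

Measured compounds:
Compound 1, `O=c1nc(SCc2ccccc2)ccn1[C@@H]1O[C@H](COP(=O)(O)OP(=O)(O)O)[C@@H](O)[C@H]1O`: 800 nM
Compound 2, `Cn1c(=O)ccn([C@@H]2O[C@H](COP(=O)(O)OP(=O)(O)O)[C@@H](O)[C@H]2O)c1=O`: 3300 nM

Both compounds were tested in an in vitro functional assay on 1321-N1 cells for agonist activity at P2Y purinoceptor 6 (Homo sapiens); a lower number here means that less compound is needed, a higher number that more compound is needed for the effect. Compound 1 gives 800 nM, the lower of the two numbers. Compound 2 gives 3300 nM, which lies beyond the usual scatter from the value of compound 1, so compound 1 needs less material for the same effect. These two compounds differ in more than one place, so no single structural change can be read off from their values.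

Compound 3, `CSc1ccn([C@@H]2O[C@H](COP(=O)(O)OP(=O)(O)O)[C@@H](O)[C@H]2O)c(=O)n1`, has not yet been tested. It is made from compound 1 by one change: hydrogen in place of phenyl on a saturated chain carbon bound to a sulfur. The benzylsulfanyl group of compound 1 thus becomes a methylsulfanyl group in compound 3.

Within the data shown here, no measured step of this kind is available, so the expectation rests on the change alone. A modest rise in the number is expected, a 2.3-fold higher number from compound 1 to compound 3 (0.35 log units; beyond the scatter), meaning compound 3 is expected to need somewhat more material than compound 1. Compound 3 is estimated at 1800 nM, with a likely range from 500 nM to 6000 nM.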

Compound 3, half-maximal effective concentration: 2300 nM
Beside the measured number, compound 3's estimate is 1.3-fold (0.11 log units) below it; the range from low to high includes it.
By their numbers in this assay, from the lowest: compound 1; then compounds 3 and 2 (each within the scatter of the next).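

In this assay, replacing the phenyl with hydrogen on the saturated chain carbon bound to the sulfur gives a 2.9-fold higher number from compound 1 to compound 3 (0.46 log units; beyond the scatter), a modest step beyond the usual scatter. Among these compounds, this is the first comparison here in which only one place changes, and it ties a real difference in the number to the phenyl ring of the benzylsulfanyl group. Compound 3 still gives a finite value of 2300 nM with only a methylsulfanyl group, so a response in this assay does not depend on that ring, although having the ring goes with needing less compound; the data offer no explanation for the size of this step.

The compounds shown leave open how the number moves with the group on sulfur between methyl and benzyl, which an ethyl group or a longer chain could help to map. They also leave open whether a chlorine or methoxy group on the phenyl ring, or an amine in place of the sulfur, would lower the number further or raise it.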